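A few compounds are considered here, and "the series" means these few. Any claim that something is new, unique, unknown or untested is made for them only; others in the source may bear on it.

In a functional assay on cells for positive allosteric modulation of metabotropic glutamate receptor 5 (Rattus norvegicus), read by calcium flux (a lower number here means that less compound is needed, a higher number that more compound is needed for the effect), compound 1 `O=C(Nc1cc(-c2ccccc2)nn1-c1ccccc1)c1cccc([N+](=O)[O-])c1` gives 39 nM and compound 2 `O=C(Nc1cc(-c2ccccc2)nn1-c1ccccc1Br)c1ccc([N+](=O)[O-])cc1` gives 61 nM. On these two numbers compound 2 stands at the higher end, yet its distance from compound 1 is within the scatter, so no order between the two can be read from them. Compound 3 `O=C(Nc1cc(-c2ccccc2)nn1-c1ccccc1Br)c1cccc([N+](=O)[O-])c1` is compound 2 with one change: 3-nitrophenyl in place of 4-nitrophenyl on a carbonyl carbon. Among the compounds with values here, compound 3 thus carries the 3-nitrophenyl of compound 1 together with the bromine-bearing ring of compound 2, and no measured pair in this small set shows what either change alone does in this assay. With the two known values lying within the scatter of each other, the change to compound 3 is expected to give a step of a 1.4-fold lower number from compound 2 to compound 3 (0.13 log units; within the scatter) that stays inside the usual scatter, and no direction is claimed for it beyond a lean toward the number of compound 1. For compound 3 the half-maximal effective concentration in this assay is therefore estimated at 45 nM, with a range from 20 nM to 110 nM.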

Compound 3, half-maximal effective concentration: 68 nM
The estimate for compound 3 lay 1.5-fold (0.18 log units) below the measured number, within the range that was stated.
By their numbers in this assay, from the lowest: compounds 1, 2 and 3 (each within the scatter of the next).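

In this assay, within the data shown here, the step of a 1.1-fold higher number from compound 2 to compound 3 (0.05 log units; within the scatter) gives the first direct comparison of 3-nitrophenyl with 4-nitrophenyl on a carbonyl carbon, and with the rest of the molecule held fixed, this read-out does not tell the two groups apart. The step of a 1.7-fold higher number from compound 1 to compound 3 (0.24 log units; within the scatter) isolates bromo in place of hydrogen on an aromatic carbon, a change that no earlier pair had shown alone, and this change, too, stays inside the scatter with 3-nitrophenyl in the molecule. No evidence is available that bears on either result.

The set leaves open whether an amine or a carboxylic acid in place of the nitro group on the phenyl ring would give a step beyond the scatter, since both nitrophenyl groups shown here carry the same nitro group. It also leaves open what bromo in place of hydrogen does when 4-nitrophenyl stands on the carbonyl carbon, and whether chloro or methoxy on that aromatic carbon would differ from bromo.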